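Swapping ethyl for difluoromethyl on the furan of compound 3

The source may report more compounds than this note shows. Statements on the series, on what has been measured and on what is new or still open speak of the compounds shown alone.

Measured compounds:
compound 1 `Cc1ccc(-c2nc(N)c3cc(-c4ccccc4)sc3n2)o1` 520 nM
compound 2 `Cc1ccc(-c2nc(N)c3cc(Cc4ccccc4Cl)sc3n2)o1` 26.1 nM
compound 3 `CCc1ccc(-c2nc(N)c3cc(Cc4ccccc4)sc3n2)o1` 223 nM

All three share one core and were tested in a functional assay on CHO-K1 cells for antagonist activity at adenosine receptor A1 (Homo sapiens), read by a beta-galactosidase reporter and cAMP accumulation, with stated times of 15 min and 6 h; on this read-out higher numbers stand for weaker inhibition and lower numbers for stronger inhibition. Among the three numbers, compound 3 with 223 nM stands second highest: compound 1 sits above it, and compound 2 lies well below it, so compound 3 is neither the weakest nor the strongest of the set. Among the compounds with values here, the only single-place step measured so far, a 20-fold lower number from compound 1 to compound 2 (1.30 log units; beyond the scatter), concerns a different part of the molecule, the group on the thiophene side of the core, and tells nothing about the furan side.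

Compound 4 `Nc1nc(-c2ccc(C(F)F)o2)nc2sc(Cc3ccccc3)cc12` differs from compound 3 only on the furan: difluoromethyl in place of ethyl on an aromatic carbon. Within the data shown here, no measured pair varies the group at this position, so nothing in the data says whether this change helps or hurts. The sensible expectation is therefore a step of no size beyond the scatter, with a wide margin either way, giving an estimated 1.0-fold lower number from compound 3 to compound 4 (0.01 log units; within the scatter) in this assay. Compound 4 is expected to give about 220 nM, in a range from 70 nM to 700 nM.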

Compound 4, inhibition constant: 3000 nM
Estimate against measurement, compound 4: 14-fold (1.13 log units) below, and the stated range ends below it.
By their numbers in this assay, from the lowest: compound 2; then compound 3; then compound 1; then compound 4.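

In this assay, difluoromethyl in place of ethyl gives a 13-fold higher number from compound 3 to compound 4 (1.13 log units; beyond the scatter), so the group on this aromatic carbon next to the ring oxygen of the furan has a large bearing on the read-out, and the change goes toward weaker inhibition. Within the data shown here, the only earlier step, a 20-fold lower number from compound 1 to compound 2 (1.30 log units; beyond the scatter), came from 2-chlorobenzyl in place of phenyl and said nothing about this position; it is now clear that a small group here, at the other site of change, can also produce a large step, even though only one heavy atom separates the size of the two groups. No measurement at hand bears on why this swap weakens inhibition.

Going by these compounds, a single step cannot separate the loss of ethyl from the arrival of difluoromethyl, so it remains open whether a propyl chain, a methoxy group or a trifluoromethyl group at this position would stay close to compound 3 or move toward compound 4. On these data alone, it is also open whether the same swap would cost as much on a compound carrying 2-chlorobenzyl, as compound 2 does, since the two sites have not been seen changing together.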